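Vinyl sulfide series: halophenyl swap on the alkene carbon

The compounds below may be only part of what the source reports. "The series", "measured", "known", "first", "only" and "open" are said of these compounds alone.

Of the compounds shown here, two have numbers so far. Compound 1 `Cc1ccc(CS/C(=C/c2ccc(F)c(C)c2)C(=O)c2ccc(Cl)cc2)cc1` gives 25000 nM in a functional assay on DU-145 cells (Homo sapiens) for inhibition, read by trypan blue exclusion, with a stated time of 96 h (a higher number here means a weaker inhibitor of growth, a lower number a stronger inhibitor of growth), and stands as the higher of the two numbers. Compound 2 `COc1ccc(/C=C(\C(=O)c2ccc(Br)cc2)S(=O)(=O)c2ccc(Br)cc2)c(OC)c1` gives 8000 nM in this assay, a lower number that lies beyond the usual scatter; compound 2 differs from compound 1 at several places at once, so nothing can be drawn from that gap about any single change.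

Compound 3 `Cc1ccc(CS/C(=C/c2ccc(Cl)cc2)C(=O)c2ccc(Cl)cc2)cc1` has not been measured. Against compound 1 the difference is 4-chlorophenyl in place of 4-fluoro-3-methylphenyl on a double-bonded chain carbon bound to a double-bonded chain carbon. Within the data shown here, no measured pair shows the effect of this change in this assay. Without such a pair, the expectation is a step of no clear size, in either direction, within the usual scatter: the estimated step is a 1.3-fold lower number from compound 1 to compound 3 (0.10 log units; within the scatter). For compound 3 the expected value in this assay is 20000 nM, with a range from 7000 nM to 60000 nM.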

Compound 3, concentration for 50% growth inhibition: 10000 nM
The estimate for compound 3 lay 2.0-fold (0.30 log units) above the measured number; low and high end bracket the measured number.
By their numbers in this assay, from the lowest: compounds 2 and 3 (each within the scatter of the next); then compound 1.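

At this position, on a double-bonded chain carbon bound to a double-bonded chain carbon, this assay now has a single change to read: 4-chlorophenyl in place of 4-fluoro-3-methylphenyl gives a 2.5-fold lower number from compound 1 to compound 3 (0.40 log units; beyond the scatter) and so the number is not indifferent to the group placed here. The swap alters the halogen and removes the methyl together, so this one step does not apportion the shift between them. No measurement in hand bears on why the number moves.

Still open, as far as these compounds go, is whether the loss of the methyl, the loss of the fluorine or the gain of the chlorine carries the step. Also open, from the compounds shown here alone, is how the number responds at this position to a phenyl bearing an amine or a carboxylic acid.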